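Methoxy Addition in a Three-Compound Cytotoxicity Series

This account rests on a few compounds, and the source may have more. Where it says the series, first, only, none or still open, it means among the compounds named here.

Measured in a functional assay on MDA-MB-468 cells (Homo sapiens) for cytotoxicity, read by sulforhodamine B assay, with a stated time of 48 h, tested at 1 uM; on this read-out lower numbers stand for a stronger effect and higher numbers for a weaker effect at the one concentration tested:
- compound 1 `COc1ccc(-c2cc(/C=C/C(=O)c3ccc(N)cc3)[nH]n2)cc1` gives 29%
- compound 2 `COc1ccc(C(=O)/C=C/c2cc(-c3cc(OC)c(OC)c(OC)c3)n[nH]2)cc1OC` gives 45%
- compound 3 `COc1ccc(-c2cc(/C=C/C(=O)c3ccc(N)cc3)[nH]n2)cc1OC` gives 77%

Compounds 1 and 3 differ in one place: methoxy in place of hydrogen on an aromatic carbon. The step is a number 48 percentage points higher from compound 1 to compound 3 (beyond the scatter), which on this read-out means a weaker effect at the single concentration. Compound 2 differs from compound 1 in more than one place; the difference between the two cores is not broken down here. Compound 2 stands second highest of the three numbers, with compound 1 nearest and compound 3 furthest.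

Compound 4 `COc1cc(C(=O)/C=C/c2cc(-c3cc(OC)c(OC)c(OC)c3)n[nH]2)cc(OC)c1OC` is not yet measured. It relates to compound 2 as compound 3 relates to compound 1: methoxy in place of hydrogen on an aromatic carbon. The place is not identical, since in compound 4 the entering methoxy also sits meta to a methoxy group, so this is the same kind of change rather than the same change. Going by the values given here, only one measured pair carries this change, so the direction is carried over with more confidence than the size. In this assay a step of a number 30 percentage points higher from compound 2 to compound 4 (beyond the scatter) is expected, because the earlier pair gave a number 48 percentage points higher from compound 1 to compound 3 (beyond the scatter). A somewhat smaller step than before is expected, as compound 2 already stands at 45% and the read-out has limited room to rise. Compound 4 is estimated at 75%, with a range from 52% to 96%.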

Compound 4, a percentage reported as activity, at one concentration (the size of the read-out at that concentration, not a potency): 59%
For compound 4 the middle estimate is 16 percentage points above the measured one; low and high end bracket the measured number.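

In this assay, methoxy in place of hydrogen on an aromatic carbon again goes with a weaker effect at the single concentration, with a number 14 percentage points higher from compound 2 to compound 4 (beyond the scatter). The direction therefore holds on both cores, but the size of the step does not carry over from one core to the other: the same change on two cores in this assay, a number 48 percentage points higher (beyond the scatter) from compound 1 to compound 3 and a number 14 percentage points higher (beyond the scatter) from compound 2 to compound 4, 34 percentage points apart, beyond the scatter of two such steps These two pairs do not show what sets the size, since the cores differ and the place of the entering methoxy is not identical on them, and they say nothing about the direction on any further core.

The compounds shown leave open whether a hydroxyl group, a fluorine atom or a longer chain such as ethoxy in place of that same hydrogen would give a step in the same direction. Also open, as far as these compounds go, is whether the effect would be stronger or weaker at any other concentration, as each compound appears at one concentration only.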